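From a Fluorobenzyl Group to a Phenylethyl Group

The source may hold more compounds than are shown below. What is called first, only, known or untested is meant among the compounds shown, and "the series" means these compounds.

Compound 2 `N#Cc1cccc(-c2nc(N)c3cc(Cc4ccccc4F)sc3n2)c1` was tested in a functional assay on CHO-K1 cells for antagonist activity at adenosine receptor A1 (Homo sapiens), read by a beta-galactosidase reporter and cAMP accumulation, with stated times of 15 min and 6 h; on this read-out higher numbers stand for weaker inhibition and lower numbers for stronger inhibition. In this assay compound 2 gives only a limit, < 16 nM, and so it sits at the limit of < 16 nM in this assay, at which 1 of the 2 values shown sits. Compound 1 `Cc1csc(-c2nc(N)c3cc(C(C)c4ccccc4)sc3n2)n1` differs from compound 2 in more than one place; in this assay compound 1 gives 1420 nM. Compound 3 `CC(c1ccccc1)c1cc2c(N)nc(-c3cccc(C#N)c3)nc2s1` is not yet measured. Its change from compound 2 is 1-phenylethyl in place of 2-fluorobenzyl on an aromatic carbon. With compound 2 resting at a limit, the step is expected to be an at least 3.7-fold higher number from compound 2 to compound 3 (0.57 log units; beyond the scatter), toward weaker inhibition. Compound 3 is accordingly estimated at 60 nM in this assay, within 10 nM to 350 nM.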

Compound 3, inhibition constant: 1770 nM
Beside the measured number, compound 3's estimate is 30-fold (1.47 log units) below it; measured number above the stated range.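

In this assay, 1-phenylethyl in place of 2-fluorobenzyl on an aromatic carbon next to the ring sulfur gives an at least 110-fold higher number from compound 2 to compound 3 (2.04 log units; beyond the scatter), so this position responds strongly to this change. The value of compound 2 is a limit and not a number: the limit of < 16 nM in this assay, at which 1 of the 3 values shown sits. With 1-phenylethyl at this position, 3-cyanophenyl in place of 4-methyl-1,3-thiazol-2-yl gives a 1.2-fold higher number from compound 1 to compound 3 (0.10 log units; within the scatter).

From the compounds shown here alone, what a plain benzyl or a 1-(2-fluorophenyl)ethyl group would give at this position stays open, and with it whether the fluorine or the branching carbon carries the step. Also open, going by these compounds, is how 4-methyl-1,3-thiazol-2-yl behaves alongside 2-fluorobenzyl.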